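Acyl variation on a shared core: from compound 3 to compound 4

A few compounds are considered here, and "the series" means these few. Any claim that something is new, unique, unknown or untested is made for them only; others in the source may bear on it.

Measured so far in an assay on SH-EP1 cells for agonist activity at Neuronal acetylcholine receptor; alpha4/beta2 (Homo sapiens), read by FLIPR and calcium flux; a lower number here means a smaller maximal response, a higher number a larger maximal response:
compound 1 `CC(=O)N1CC2CC(C1)N2`: 95%
compound 2 `CCC(=O)N1CC2CC(C1)N2`: 110%
compound 3 `O=C(C1CCC1)N1CC2CC(C1)N2`: 99%

Compound 3 stands second highest of the three numbers; its value lies within the scatter of compound 1 and is set apart from compound 2 by a number 11 percentage points lower from compound 2 to compound 3 (beyond the scatter). Compound 4 `O=C([C@@H]1C[C@H]1F)N1CC2CC(C1)N2` differs from compound 3 by 2-fluorocyclopropyl in place of cyclobutyl on a carbonyl carbon. Going by the values given here, the measured steps that bear on this place are a number 15 percentage points higher from compound 1 to compound 2 (beyond the scatter), a number 4 percentage points higher from compound 1 to compound 3 (within the scatter) and a number 11 percentage points lower from compound 2 to compound 3 (beyond the scatter); every change on the carbonyl carbon so far has moved the maximal response modestly at most, and no measured pair covers 2-fluorocyclopropyl. A step within the scatter, or at most modest in either direction, is therefore expected in this assay. Compound 4 is estimated at 95%, range 75% to 115%, which means an expected step of a number 4 percentage points lower from compound 3 to compound 4 (within the scatter).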

Compound 4, largest response reached (Emax), in percent of the reference or control that the assay uses: 110%
Compound 4: middle estimate off by 15 percentage points, on the low side; the range from low to high includes it.
By their numbers in this assay, from the lowest: compounds 1 and 3 (each within the scatter of the next); then compounds 2 and 4 (each within the scatter of the next).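

In this assay, 2-fluorocyclopropyl on the carbonyl carbon gives a number 11 percentage points higher from compound 3 to compound 4 (beyond the scatter) and a number 15 percentage points higher from compound 1 to compound 4 (beyond the scatter), with no change at the digits printed from compound 2 to compound 4 (within the scatter). Going by these compounds alone, a ring at this place therefore need not stay at the level of compound 3; among the earlier compounds, only the ethyl of compound 2 reached the upper level. Nothing available explains the gap between the two rings.

Whether the fluorine or the three-membered ring accounts for the step remains open, and a plain cyclopropyl would help separate the two. Going by these compounds, the opposite stereoisomer of 2-fluorocyclopropyl and a longer chain such as butyl also remain open.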